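The source may report more compounds than this note shows. Statements on the series, on what has been measured and on what is new or still open speak of the compounds shown alone.

Working notes on the series. The shared core carries a phenyl group and a side group that varies: compound 1 `Nc1cc(N)c2nc(-c3ccccc3)c(Oc3ccc(Cl)c(Cl)c3)nc2c1`, compound 2 `Nc1cc(N)c2nc(-c3ccccc3)c(NCc3ccc(Cl)c(Cl)c3)nc2c1` and compound 3 `COc1ccc(CNc2nc3cc(N)cc(N)c3nc2-c2ccccc2)cc1OC`. In a functional assay on UO-31 cells (Homo sapiens) for inhibition, read by sulforhodamine B assay, with a stated time of 48 h (on this read-out higher numbers stand for lower toxicity in this test and lower numbers for higher toxicity in this test), compound 1 gives < 100000 nM, a limit of the test rather than a number. In this assay compound 2 gives < 100000 nM, again a limit. In this assay compound 3 gives < 100000 nM, also a limit. The step that the two limits leave unreadable from compound 2 to compound 3 therefore cannot be sized. Compound 3 thus stands only at a limit, as do the other two values shown (the limit of < 100000 nM in this assay, at which 3 of the 3 values shown sit).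

The next compound is compound 4 `Nc1cc(N)c2nc(-c3ccccc3)c(NCc3ccc(F)cc3)nc2c1`. Its change from compound 3 is 4-fluorophenyl in place of 3,4-dimethoxyphenyl on a saturated chain carbon bound to a nitrogen on an aromatic ring. Among the measured compounds shown here, the only measured step with the same place, from compound 2 to compound 3, is unreadable, so no measured step bears on the expected size of this one.

In this assay the step from compound 3 to compound 4 is expected to be a step that the limit leaves unreadable from compound 3 to compound 4, not readable beyond the limits. In this assay compound 4 is estimated at 30000 nM, in the range 5000 nM to 100000 nM.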

Compound 4, concentration lethal to 50% of the cells: < 100000 nM
Compound 4: no number, only a limit; the forecaster's own chance of this, stated with the estimate: 40%; the middle value lies beyond the limit too.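

In this assay compound 4 gives < 100000 nM, a limit and not a number. The steps linking compound 4 to compound 1, compound 2 and compound 3 therefore cannot be read. The compounds shown leave open whether these side groups differ at all in this assay, with every value resting on one limit: the limit of < 100000 nM in this assay, at which 4 of the 4 values shown sit.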